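Moving two fluorines on the acyl phenyl of compound 2

This account rests on a few compounds, and the source may have more. Where it says the series, first, only, none or still open, it means among the compounds named here.

Measured compounds and their values:
- compound 1 `CN(C(=O)NC(=O)c1cccc(C(F)(F)F)c1)c1nc(C(F)(F)F)c(C(=O)N/N=C/c2ccc(C(F)(F)F)cc2)s1`: 7.35 ug/mL
- compound 2 `CN(C(=O)NC(=O)c1ccc(F)c(F)c1)c1nc(C(F)(F)F)c(C(=O)N/N=C/c2cc(C(F)(F)F)cc(C(F)(F)F)c2)s1`: 4.45 ug/mL
- compound 3 `CN(C(=O)NC(=O)c1ccc(F)c(F)c1)c1nc(C(F)(F)F)c(C(=O)N/N=C/c2cccc(C(F)(F)F)c2)s1`: 4.21 ug/mL

All three compounds were tested in a functional assay on HeLa cells (Homo sapiens) for inhibition, read by MTT assay, with a stated time of 72 h; a lower number here means a stronger inhibitor, a higher number a weaker inhibitor. Compound 1 gives 7.35 ug/mL, compound 2 gives 4.45 ug/mL and compound 3 gives 4.21 ug/mL. Compound 2 stands second highest of the three numbers, within the scatter of both neighbours: compound 3 lies closest, compound 1 furthest, and neither gap is beyond the scatter.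

Compound 4 `CN(C(=O)NC(=O)c1c(F)cccc1F)c1nc(C(F)(F)F)c(C(=O)N/N=C/c2cc(C(F)(F)F)cc(C(F)(F)F)c2)s1` is not yet measured. It differs from compound 2 by 2,6-difluorophenyl in place of 3,4-difluorophenyl on a carbonyl carbon; the two compounds have the same atoms, joined differently.

Among the compounds with values here, only one single-point step is known among the measured compounds, a 1.1-fold lower number from compound 2 to compound 3 (0.02 log units; within the scatter), and it concerns the other phenyl ring, not the acyl phenyl that changes here. Within the data shown here, no measured step moves fluorines around on the acyl phenyl, so the bearing of the known data on this change is indirect at best. With the three numbers lying within the scatter of one another and no step beyond the scatter anywhere, the author expects no step beyond the scatter in this assay for a 1.1-fold higher number from compound 2 to compound 4 (0.05 log units; within the scatter). Compound 4 is therefore estimated at 5 ug/mL, in a range from 2.2 ug/mL to 12 ug/mL.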

Compound 4, half-maximal inhibitory concentration: 5.62 ug/mL
Compound 4: middle estimate off by 1.1-fold (0.05 log units), on the low side, and the stated range covers the measured number.
By their numbers in this assay, from the lowest: compounds 3, 2, 4 and 1 (each within the scatter of the next).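

In this assay, within the data shown here, a 1.3-fold higher number from compound 2 to compound 4 (0.10 log units; within the scatter) is the first measured step at the acyl phenyl, so the earlier compounds could not show what happens when the fluorines on that ring are rearranged. The exchange of 3,4-difluorophenyl for 2,6-difluorophenyl on this carbonyl carbon stays within the scatter, as does a 1.1-fold lower number from compound 2 to compound 3 (0.02 log units; within the scatter) on the other phenyl, so neither of the two places probed by a single change has yet given a clear difference in this assay. Nothing measured here speaks to the reason for this outcome.

All the acyl rings shown carry fluorine or trifluoromethyl, and compound 1 differs from the others in more than one place, so its number isolates no single change at the acyl phenyl. As far as these compounds go, it remains open whether an unsubstituted phenyl, a phenyl bearing an amine or a carboxylic acid, or a pyridine in place of the phenyl on this carbonyl carbon would give a step beyond the scatter.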